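Aziridinyl quinone series: replacing the ring amine

A few compounds are considered here, and "the series" means these few. Any claim that something is new, unique, unknown or untested is made for them only; others in the source may bear on it.

Compound 1 `O=C1C=C(N2CC2)C(=O)c2nc(-c3ccccc3)ccc21` is the stronger of the two measured compounds in a functional assay on NCI60 cells (Homo sapiens) for cytotoxicity; a higher number here means a weaker inhibitor of growth, a lower number a stronger inhibitor of growth: compound 1 gives 85.1 nM, the lowest of the two numbers shown. Compound 2 `Cc1ccc2c(n1)C(=O)C=C(N1CC1)C2=O`, which carries a methyl group where compound 1 carries a phenyl, sits apart in this assay: compound 2 gives 513 nM, and the gap between the two lies beyond the scatter.

Compound 3 `COCCCNC1=CC(=O)c2ccc(-c3ccccc3)nc2C1=O` has not been measured. It keeps the phenyl of compound 1 and differs in one place: (3-methoxypropyl)amino in place of aziridin-1-yl on a double-bonded ring carbon. Among the compounds with values here, no measured pair shows a change of this kind, so neither direction nor size is anchored by any step in the set. The only measured variation concerns phenyl versus methyl; the numbers say nothing about the nitrogen substituent on the double-bonded ring carbon.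

Taken as an open change, the expectation is a move toward weaker growth inhibition in this assay, of moderate size and with a wide margin. Compound 3 is estimated at 400 nM, with a range of 100 nM to 2000 nM. The expected step is a 4.7-fold higher number from compound 1 to compound 3 (0.67 log units; beyond the scatter).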

Compound 3, concentration for 50% growth inhibition: 5500 nM
For compound 3 the middle estimate is 14-fold (1.14 log units) below the measured one, and the stated range ends below it.
By their numbers in this assay, from the lowest: compound 1; then compound 2; then compound 3.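

The double-bonded ring carbon now has its first measured step: in this assay, with the phenyl kept, (3-methoxypropyl)amino in place of aziridin-1-yl gives a 65-fold higher number from compound 1 to compound 3 (1.81 log units; beyond the scatter) and is a large loss of growth inhibition. The nitrogen substituent at this place therefore matters strongly in this assay, which the phenyl and methyl pair could not show, and aziridin-1-yl is the better of the two groups compared here. Within the data shown here, the single step changes several things at once, since a three-membered ring gives way to an open chain, a hydrogen-bond donor enters and the group grows, and nothing measured here bears on which of these accounts for the step.

Still open, from the compounds shown here alone, is whether the loss follows the opening of the ring or the length of the chain, which a plain amino group, dimethylamino or an azetidine ring on the same carbon would help to separate. Also open, going by these compounds, is whether the step keeps its size when methyl, as in compound 2, stands in place of the phenyl.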